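Dropping One Chloro Where Every Value So Far Is a Limit

The source may report more compounds than this note shows. Statements on the series, on what has been measured and on what is new or still open speak of the compounds shown alone.

Compound 1 `CC1(C)CC(=O)C=C(Nc2ccc(Cl)cc2Cl)C1` gives in a functional assay on PBMC cells (Homo sapiens) for inhibition, read by ELISA, with a stated time of 18 h (on this read-out lower numbers stand for stronger inhibition and higher numbers for weaker inhibition), only a limit, > 20 ug/mL.
Compound 2 `CCCCSC(=S)C1=C(Nc2ccc(Cl)cc2Cl)CC(C)(C)CC1=O` gives in this assay only a limit, > 20 ug/mL.
Compound 3 `CC1(C)CC(=O)C(C(=S)SCCO)=C(Nc2ccc(Cl)cc2Cl)C1` gives in this assay only a limit, > 20 ug/mL.

Compound 1 thus stands nowhere that can be placed on a scale: its value is a limit, and the same holds for the two other compounds, as the limit of > 20 ug/mL in this assay, at which 3 of the 3 values shown sit, shows. The changes among the measured compounds, a step that the two limits leave unreadable from compound 1 to compound 2, a step that the two limits leave unreadable from compound 1 to compound 3 and a step that the two limits leave unreadable from compound 2 to compound 3, are unreadable in size and direction for that reason. Compound 4 `CC1(C)CC(=O)C=C(Nc2ccc(Cl)cc2)C1` differs from compound 1 by hydrogen in place of chloro on an aromatic carbon. For the measured compounds named here, none of the measured changes touches the aromatic ring, so they bear on this change only indirectly, by showing that the shared core has not yet produced a readable number in this assay. The step that the limit leaves unreadable from compound 1 to compound 4 is therefore expected to be small or to remain hidden behind a limit. For compound 4 the estimate is 30 ug/mL, with a range from 8 ug/mL to 100 ug/mL, and a limit rather than a number is expected to be the most likely outcome.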

Compound 4, half-maximal inhibitory concentration: > 20 ug/mL
Compound 4 gave a limit, no number (the forecaster's own chance of this, stated with the estimate: 75%); the middle value is on the limit's open side.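

Compound 1 and compound 4 each give only a limit, not a number, so no step between them can be read: the limit of > 20 ug/mL in this assay, at which 4 of the 4 values shown sit.

The compounds shown leave open how strongly any of them inhibits in this assay, and whether hydrogen in place of chloro changes that at all.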